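The source may report more compounds than this note shows. Statements on the series, on what has been measured and on what is new or still open speak of the compounds shown alone.

Of the compounds shown here, two of a shared core have been tested in a functional assay on HL-60 cells (Homo sapiens) for cytotoxicity, read by MTT assay, with a stated time of 24 h; a higher number here means a weaker inhibitor, a lower number a stronger inhibitor. Compound 1 `OCCOc1c(Br)cc(Br)cc1Oc1ccc(Br)cc1Br` gives 28.2 ug/mL in this assay. Compound 2 `C=CCOc1c(Br)cc(Br)cc1Oc1ccc(Br)cc1Br` gives 27.9 ug/mL in this assay, and the step of a 1.0-fold lower number from compound 1 to compound 2 (0.00 log units; within the scatter) shows that exchanging the end of the chain on the saturated chain carbon bound to an oxygen on an aromatic ring left the number within the scatter, so the values of compound 2 and compound 1 cannot be told apart.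

Compound 3 `Brc1ccc(Oc2cc(Br)cc(Br)c2OCc2ccccc2)c(Br)c1` has not been measured. It differs from compound 2 by phenyl in place of vinyl on a saturated chain carbon bound to an oxygen on an aromatic ring. Among the compounds with values here, the one measured step that touches this position, from compound 1 to compound 2, was flat, and nothing measured shows what the entering phenyl does, so the expectation for this assay rests on that flat step alone. Compound 3 is therefore expected to give 25 ug/mL, between 12 ug/mL and 50 ug/mL, a step of a 1.1-fold lower number from compound 2 to compound 3 (0.05 log units; within the scatter) that is expected to stay within the scatter.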

Compound 3, half-maximal inhibitory concentration: 27.9 ug/mL
The estimate for compound 3 lay 1.1-fold (0.05 log units) below the measured number, within the range that was stated.
By their numbers in this assay, from the lowest: compounds 2, 3 and 1 (each within the scatter of the next).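

The step of no change at the digits printed from compound 2 to compound 3 (within the scatter) shows that in this assay a phenyl, with its six-membered aromatic ring of carbon only, can take the place of vinyl on a saturated chain carbon bound to an oxygen on an aromatic ring without a readable shift in the number. The step of a 1.0-fold lower number from compound 1 to compound 3 (0.00 log units; within the scatter) adds that phenyl and hydroxymethyl cannot be told apart at this place either, so the three ends shown, differing in size and in ring content, all give values within the scatter of one another. Nothing further measured bears on this result.

The compounds shown leave open whether any end at this place can move the number beyond the scatter. Going by these compounds, an amine, a carboxylic acid or a longer chain here remains untested among them, as does any change to the bromines of the shared core.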